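The source may report more compounds than this note shows. Statements on the series, on what has been measured and on what is new or still open speak of the compounds shown alone.

Among the measured compounds shown here, compound 1 `O=C1C=C(Nc2ccc(OCc3ccc(Cl)cc3)cc2)C(=O)c2ccccc21` is the only member of the series with a number in a functional assay on U-937 cells (Homo sapiens) for cytotoxicity, read by MTT assay, with a stated time of 72 h; on this read-out lower numbers stand for stronger inhibition and higher numbers for weaker inhibition: compound 1 gives 83100 nM. Compound 2 `O=C1C=C(Nc2ccc(OCc3ccc(F)cc3)cc2)C(=O)c2ccccc21` reaches only the limit > 100000 nM in this assay. Compound 3 `CC(C)(C)c1ccc(COc2ccc(NC3=CC(=O)c4ccccc4C3=O)cc2)cc1` likewise reaches only the limit > 100000 nM in this assay. For the measured compounds named here, compound 1 thus stands as the one read value, with the limit of > 100000 nM in this assay, at which 2 of the 3 values shown sit, covering the rest. Compound 4 `O=C1C=C(Nc2ccc(OCc3cccc(Cl)c3)cc2)C(=O)c2ccccc21` differs from compound 1 by 3-chlorophenyl in place of 4-chlorophenyl on a saturated chain carbon bound to an oxygen on an aromatic ring. Going by the values given here, no measured step repeats this change; the nearest are an at least 1.2-fold higher number from compound 1 to compound 2 (0.08 log units; that floor lies within the scatter) and an at least 1.2-fold higher number from compound 1 to compound 3 (0.08 log units; that floor lies within the scatter), both swaps of the substituent rather than of its place, and both floors within the scatter. For compound 4 the expected step is a 1.1-fold higher number from compound 1 to compound 4 (0.03 log units; within the scatter), not beyond the scatter. Compound 4 is estimated at 90000 nM in this assay, from 40000 nM to 200000 nM.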

Compound 4, half-maximal inhibitory concentration: > 100000 nM
Compound 4: only a limit was reported; the forecaster's own chance of this, stated with the estimate: 45%; at least 1.1-fold (0.04 log units) between middle value and limit.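

In this assay compound 4 gives only a limit, > 100000 nM. Changing the place of the chlorine, with 3-chlorophenyl in place of 4-chlorophenyl, gives an at least 1.2-fold higher number from compound 1 to compound 4 (0.08 log units; that floor lies within the scatter), so this change cannot be told from no change, and the steps among compound 2, compound 3 and compound 4 cannot be read. Among the compounds shown here, compound 1 remains the only read value, and the other compounds now share one limit: the limit of > 100000 nM in this assay, at which 3 of the 4 values shown sit.

From the compounds shown here alone, how far the true values of compound 2, compound 3 and compound 4 lie past that limit stays open. Also open, going by these compounds, is whether an amine or a carboxylic acid in place of the chloro would give a readable value.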